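Methylpiperazine Added to the Cyclohexylamino Analog

This account rests on a few compounds, and the source may have more. Where it says the series, first, only, none or still open, it means among the compounds named here.

Among the three measured compounds, compound 3 `N=C(Nc1ccccc1)c1cc2c(-c3ccccc3)n[nH]c2c(NC2CCCCC2)n1` stands lowest in a functional assay on PC-3 cells (Homo sapiens) for cytotoxicity, read by MTT assay, with a stated time of 72 h (on this read-out higher numbers stand for weaker inhibition and lower numbers for stronger inhibition), where compound 3 gives 1730 nM. Among the compounds with values here, compound 1 `COc1cc(Nc2nc(C(=N)Nc3ccc(N4CCN(C)CC4)cc3)cc3c(-c4ccccc4)n[nH]c23)cc(OC)c1OC` gives 4300 nM in this assay, and compound 2 `COc1cc(Nc2nc(C(=N)Nc3ccccc3)cc3c(-c4ccccc4)n[nH]c23)cc(OC)c1OC` gives 5800 nM; the step of a 3.4-fold lower number from compound 2 to compound 3 (0.53 log units; beyond the scatter) is the one change that moved the numbers beyond the scatter. Compound 4 `CN1CCN(c2ccc(NC(=N)c3cc4c(-c5ccccc5)n[nH]c4c(NC4CCCCC4)n3)cc2)CC1` differs from compound 3 by 4-methylpiperazin-1-yl in place of hydrogen on an aromatic carbon. Within the data shown here, the step of a 1.3-fold higher number from compound 1 to compound 2 (0.13 log units; within the scatter) removed this same group from the same place and stayed within the scatter, so its reverse is the only guide here; the step of a 3.4-fold lower number from compound 2 to compound 3 (0.53 log units; beyond the scatter) does not touch the group that enters. The author therefore expects a step of a 1.2-fold lower number from compound 3 to compound 4 (0.09 log units; within the scatter), with no change beyond the scatter. Compound 4 is estimated at 1400 nM, ranging from 600 nM to 3500 nM.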

Compound 4, half-maximal inhibitory concentration: 4630 nM
Beside the measured number, compound 4's estimate is 3.3-fold (0.52 log units) below it; measured number above the stated range.
By their numbers in this assay, from the lowest: compound 3; then compounds 1, 4 and 2 (each within the scatter of the next).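

In this assay, adding 4-methylpiperazin-1-yl at this aromatic carbon is not a neutral change on every core: with cyclohexyl on the nitrogen it gives a 2.7-fold higher number from compound 3 to compound 4 (0.43 log units; beyond the scatter), so its outcome depends on the group on that nitrogen: the same change on two cores in this assay, a 1.3-fold higher number (0.13 log units; within the scatter) from compound 1 to compound 2 and a 2.7-fold lower number (0.43 log units; beyond the scatter) from compound 4 to compound 3, 3.6-fold (0.56 log units) apart, beyond the scatter of two such steps. The exchange of 3,4,5-trimethoxyphenyl for cyclohexyl is likewise tied to its partner, since with 4-methylpiperazin-1-yl present it gives a 1.1-fold higher number from compound 1 to compound 4 (0.03 log units; within the scatter): the same change on two cores in this assay, a 3.4-fold lower number (0.53 log units; beyond the scatter) from compound 2 to compound 3 and a 1.1-fold higher number (0.03 log units; within the scatter) from compound 1 to compound 4, 3.6-fold (0.56 log units) apart, beyond the scatter of two such steps.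

The compounds shown leave open whether the higher number on the cyclohexyl core follows the whole ring or its methyl group. A morpholine ring or an unsubstituted piperazine on the same carbon would bear on that.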